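Chloro for fluoro, with no measured starting point

The compounds below may be only part of what the source reports. "The series", "measured", "known", "first", "only" and "open" are said of these compounds alone.

In a functional assay on B16-F10 cells (Mus musculus) for inhibition, read by MTT assay, with a stated time of 72 h (on this read-out higher numbers stand for weaker inhibition and lower numbers for stronger inhibition), compound 2 `CC1(C)CC(NC(=O)Nc2ccccc2Cl)c2cc(F)ccc2O1` offers no number to start from: compound 2 is recorded as "not determined" (no result reported). Compound 4 `CC1(C)CC(NC(=O)Nc2ccccc2Cl)c2cc(Cl)ccc2O1` differs from it by a single exchange, (chloro in place of fluoro on an aromatic carbon), chloro in place of fluoro on an aromatic carbon. The same exchange links a second pair, in which compound 1 `CC1(C)CC(NC(=S)Nc2ccc(C#N)cc2)c2cc(F)ccc2O1` gives 5000 nM and compound 3 `CC1(C)CC(NC(=S)Nc2ccc(C#N)cc2)c2cc(Cl)ccc2O1` gives 7000 nM. That pair shows a 1.4-fold higher number from compound 1 to compound 3 (0.15 log units; within the scatter), so no step beyond the scatter is expected from this exchange in this assay. Compound 4 also differs from compound 3 elsewhere in the structure, so the expectation, anchored on compound 3 at 7000 nM, stays wide. Compound 4 is estimated at 8000 nM, with an expected range from 2000 nM to 40000 nM.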

Compound 4, half-maximal inhibitory concentration: 20000 nM
Compound 4: middle estimate off by 2.5-fold (0.40 log units), on the low side; the measured number falls inside the stated range.
By their numbers in this assay, from the lowest: compounds 1 and 3 (each within the scatter of the next); then compound 4.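

Among the compounds shown here, no step from compound 2 to compound 4 can be read in this assay, where compound 2 has no number. The compounds shown leave open what chloro in place of fluoro does within this pair. Nothing shown offers an explanation for the value of compound 4.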